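The source may hold more compounds than are shown below. What is called first, only, known or untested is meant among the compounds shown, and "the series" means these compounds.

Among the compounds with values here, in a functional assay on MDA-MB-231 cells (Homo sapiens) for cytotoxicity, read by MTT assay, with a stated time of 72 h (on this read-out lower numbers stand for stronger inhibition and higher numbers for weaker inhibition), compound 1 (`O=C(CN1CCN(c2nnc(Cc3ccccc3)c3ccccc23)CC1)Nc1c(F)cccc1F`) gives 5490 nM and is the higher of the two numbers so far. Compound 2 (`O=C(CN1CCN(c2nnc(Cc3ccncc3)c3ccccc23)CC1)Nc1cccc(Br)c1`) gives 1.7 nM and lies far lower, well beyond the scatter. Compound 3 (`COc1ccc(NC(=O)CN2CCN(c3nnc(Cc4ccccc4)c4ccccc34)CC2)cc1OC`) keeps the core of compound 1 and puts 3,4-dimethoxyphenyl in place of 2,6-difluorophenyl on an amide-type nitrogen. Within the data shown here, no measured step covers this change, so the expectation is uncertain. Compound 2 at 1.7 nM shows that far lower numbers occur here, so a drop beyond the scatter is expected. The estimated step (an 18-fold lower number from compound 1 to compound 3 (1.26 log units; beyond the scatter)) is a sizeable one. The estimate for compound 3 is 300 nM (expected range 15 nM to 6000 nM).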

Compound 3, half-maximal inhibitory concentration: 32200 nM
Compound 3: the middle estimate sits 110-fold (2.03 log units) below what was measured; measured number outside the range, above it.
By their numbers in this assay, from the lowest: compound 2; then compound 1; then compound 3.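

Putting 3,4-dimethoxyphenyl in place of 2,6-difluorophenyl on the amide-type nitrogen gives a 5.9-fold higher number from compound 1 to compound 3 (0.77 log units; beyond the scatter) in this assay. Within the data shown here, this is the first direct evidence that the group at this position alone can shift the number, and here the shift is upward, towards weaker inhibition. Nothing available explains the rise.

As far as these compounds go, the swap removes the fluorines and adds the methoxy groups in a single step, so it remains open which of these matters. A plain phenyl or a cyclohexyl on the same nitrogen could help separate the two.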